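Halogen Swap: Bromo to Iodo in Calpain-1 Inhibition

The source may report more compounds than this note shows. Statements on the series, on what has been measured and on what is new or still open speak of the compounds shown alone.

Compound 1 `O=C(O)/C(S)=C/c1ccccc1Cl` gives 20700 nM in an assay on isolated protein for inhibition of Calpain-1 catalytic subunit (Sus scrofa); on this read-out higher numbers stand for weaker inhibition and lower numbers for stronger inhibition.
Compound 2 `O=C(O)/C(S)=C/c1ccccc1Br` gives 9100 nM in this assay.
Compound 3 `O=C(O)/C(S)=C/c1c[nH]c2cccc(Cl)c12` gives 140 nM in this assay.

Among these three numbers, compound 2 stands second highest. Its nearest neighbour is compound 1, which gives a higher number, as the step of a 2.3-fold lower number from compound 1 to compound 2 (0.36 log units; beyond the scatter) shows. Compound 3, built on a different core, gives by far the lowest number of the three.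

Compound 4 `O=C(O)/C(S)=C/c1ccccc1I` differs from compound 2 by iodo in place of bromo on an aromatic carbon. Going by the values given here, only one measured step bears on this change: the step of a 2.3-fold lower number from compound 1 to compound 2 (0.36 log units; beyond the scatter), in which one halogen replaced another at the same place and the number fell modestly, beyond the scatter. Swapping bromo for iodo is the same kind of exchange, so a step of similar size and direction is expected in this assay, though a single precedent leaves the expectation uncertain. Compound 4 is therefore expected to give 5000 nM, within a range of 2000 nM to 15000 nM. This estimate corresponds to an expected 1.8-fold lower number from compound 2 to compound 4 (0.26 log units; within the scatter).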

Compound 4, half-maximal inhibitory concentration: 42800 nM
For compound 4 the middle estimate is 8.6-fold (0.93 log units) below the measured one; measured number outside the range, above it.
By their numbers in this assay, from the lowest: compound 3; then compound 2; then compound 1; then compound 4.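

At this place on the aromatic ring, exchanging one halogen for another does not move the number steadily in one direction: a 2.3-fold lower number from compound 1 to compound 2 (0.36 log units; beyond the scatter) goes down, but iodo in place of bromo gives a 4.7-fold higher number from compound 2 to compound 4 (0.67 log units; beyond the scatter) and reverses that fall. Iodo in place of chloro also gives a 2.1-fold higher number from compound 1 to compound 4 (0.32 log units; beyond the scatter) in the same direction, so among these three halogens at this place, bromo gives the lowest number and iodo the highest. Nothing available here accounts for this turn at iodo.

On these data alone, it remains open whether a group other than a halogen at this place, such as methyl, methoxy or an amine, would give a number lower than bromo does. Also open, as far as these compounds go, is whether bromo and iodo in place of chloro on the core of compound 3 would follow the same order.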